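A few compounds are considered here, and "the series" means these few. Any claim that something is new, unique, unknown or untested is made for them only; others in the source may bear on it.

Measured so far:
compound 1 `N#CC1=C(N)Oc2c(c3nc4ccccc4nc3c3ccccc23)C12C(=O)N(Cc1cnnn1-c1ccc(Br)cc1)c1ccccc12` — > 50000 nM
compound 2 `N#CC1=C(N)Oc2c(c3nc4ccccc4nc3c3ccccc23)C12C(=O)N(Cc1cnnn1-c1ccc([N+](=O)[O-])cc1)c1ccccc12` — > 50000 nM

In a functional assay on HCT-116 cells (Homo sapiens) for antiproliferative activity, read by MTT assay, with a stated time of 48 h (on this read-out lower numbers stand for stronger inhibition and higher numbers for weaker inhibition), compound 2 gives only a limit of the assay, > 50000 nM. Compound 1 likewise gives only a limit, > 50000 nM. The step that the two limits leave unreadable from compound 1 to compound 2 therefore has no readable size; (the limit of > 50000 nM in this assay, at which 2 of the 2 values shown sit).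

Compound 3 `N#CC1=C(N)Oc2c(c3nc4ccccc4nc3c3ccccc23)C12C(=O)N(Cc1cnnn1-c1ccc(S(N)(=O)=O)cc1)c1ccccc12` differs from compound 2 by sulfamoyl in place of nitro on an aromatic carbon. Among the measured compounds shown here, no measured step of readable size bears on this change, so no shift beyond the scatter can be argued either way. The expected step is a number no higher from compound 2 to compound 3 (the limit leaves the size open). For compound 3 the estimate is 50000 nM, with a range from 15000 nM to 100000 nM; a limit rather than a number is the most probable outcome.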

Compound 3, half-maximal inhibitory concentration: 31200 nM
Compound 3: the middle estimate sits 1.6-fold (0.20 log units) above what was measured; the range from low to high includes it.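

Among the compounds shown here, the sulfamoyl group on this aromatic carbon gives the first actual number of the series in this assay, with compound 3 at 31200 nM. Against the nitro group the result is an at least 1.6-fold lower number from compound 2 to compound 3 (0.20 log units; that floor lies within the scatter), and against the bromo group it is an at least 1.6-fold lower number from compound 1 to compound 3 (0.20 log units; that floor lies within the scatter); both are only floors, so no real gain over either group is established. The other two values remain limits rather than numbers: the limit of > 50000 nM in this assay, at which 2 of the 3 values shown sit.

Open, on these data alone, is whether an amine or a carboxylic acid on the same aromatic carbon would read lower than compound 3. Also open, as far as these compounds go, is the true distance between compound 3 and the two limit compounds.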